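The source may report more compounds than this note shows. Statements on the series, on what has been measured and on what is new or still open speak of the compounds shown alone.

Measured so far:
- compound 1 `Cc1ccccc1C(=O)Nc1ccc(Nc2ncc(C)c(-c3ccc(OC(F)(F)F)cc3)n2)cc1`: 42.1 nM in an assay on NIH3T3 cells for inhibition of Sonic hedgehog protein (Mus musculus), read by a luciferase reporter, with a stated time of 48 h; on this read-out higher numbers stand for weaker inhibition and lower numbers for stronger inhibition
- compound 2 `Cc1cnc(Nc2ccc(C(=O)Nc3c(C)cccc3C)cc2)nc1-c1ccc(OC(F)(F)F)cc1`: 1.3 nM in this assay

Among the compounds with values here, compound 2 gives the lowest of the two numbers in this assay; its nearest neighbour is compound 1, and the one measured step, a 32-fold lower number from compound 1 to compound 2 (1.51 log units; beyond the scatter), is large and lies beyond the scatter. That step changes the amide part of the shared core and says nothing directly about substitution on the trifluoromethoxy-bearing ring.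

Compound 3 `Cc1cnc(Nc2ccc(C(=O)Nc3c(C)cccc3C)cc2)nc1-c1ccc(OC(F)(F)F)c(F)c1` is the next entry. It differs from compound 2 only by fluoro in place of hydrogen on an aromatic carbon, the change sitting on an aromatic carbon of a six-membered aromatic ring of carbon only, ortho to a trifluoromethoxy group and meta to a large group; the same difference, cut one bond further out, reads 4-(trifluoromethoxy)phenyl to 3-fluoro-4-(trifluoromethoxy)phenyl. Within the data shown here, no measured pair shows this change, so no step bears on it. The working expectation is therefore no step beyond the scatter in this assay, the value staying close to compound 2.

Estimated for compound 3: 1.5 nM, range 0.5 nM to 5 nM, an expected step of a 1.2-fold higher number from compound 2 to compound 3 (0.06 log units; within the scatter).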

Compound 3, half-maximal inhibitory concentration: 159 nM
The estimate for compound 3 lay 110-fold (2.03 log units) below the measured number; the measured number lies above the stated range.
By their numbers in this assay, from the lowest: compound 2; then compound 1; then compound 3.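

In this assay the ring carrying the trifluoromethoxy group turns out not to be a silent part of the series: the step is a 120-fold higher number from compound 2 to compound 3 (2.09 log units; beyond the scatter) and it is large, although only one fluoro enters in place of hydrogen. Within the data shown here, the earlier step changed only the amide part of the shared core, so this is the first measured sign that the carbon ortho to a trifluoromethoxy group and meta to a large group matters, with 3-fluoro-4-(trifluoromethoxy)phenyl sharply worse than 4-(trifluoromethoxy)phenyl on the core of compound 2. Nothing in the data at hand accounts for the size of this step.

From the compounds shown here alone, whether chloro, methyl or methoxy on this same carbon gives a step of similar size remains open, as does whether fluoro on another carbon of this ring behaves the same way. Also open, going by these compounds, is whether the change carries over to the core of compound 1, which has ((2-methylphenyl)carbonyl)amino in place of (2,6-dimethylphenyl)carbamoyl.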